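The compounds below may be only part of what the source reports. "The series", "measured", "known", "first", "only" and "open" are said of these compounds alone.

Measured compounds:
Compound 1 `N#C[Se]c1ccc(NC(=O)Oc2ccc(F)cc2)cc1`: in an ADME assay on 184B5 cells (Homo sapiens) for cytotoxicity, read by MTT assay, with a stated time of 72 h (on this read-out higher numbers stand for weaker inhibition of growth and lower numbers for stronger inhibition of growth), compound 1 gives 6900 nM.
Compound 2 `C=CCOC(=O)Nc1ccc([Se]C#N)cc1`: in this assay compound 2 gives 5000 nM.

Among the measured compounds shown here, only two numbers are known so far. Compound 2 gives 5000 nM and compound 1 gives 6900 nM; the two lie within the usual scatter of each other, so neither compound is set apart on the shared core. For the measured compounds named here, no step between two measured compounds is known that bears on the change now in hand.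

Compound 3 `CCCCCCOC(=O)Nc1ccc([Se]C#N)cc1` is not yet measured. It differs from compound 2 in one place: pentyl in place of vinyl on a saturated chain carbon bound to an oxygen next to a carbonyl group. With no measured step of this kind in the series, the size of the step in this assay is open; a move no larger than the scatter, or a modest move toward a lower number, is expected. The expected step is a 1.4-fold lower number from compound 2 to compound 3 (0.15 log units; within the scatter). Compound 3 is estimated at 3500 nM, with an expected range from 1500 nM to 8000 nM.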

Compound 3, concentration for 50% growth inhibition: 4600 nM
Compound 3: middle estimate off by 1.3-fold (0.12 log units), on the low side; the range from low to high includes it.
By their numbers in this assay, from the lowest: compounds 3, 2 and 1 (each within the scatter of the next).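

In this assay, pentyl in place of vinyl on a saturated chain carbon bound to an oxygen next to a carbonyl group gives a 1.1-fold lower number from compound 2 to compound 3 (0.04 log units; within the scatter), the first step read at this position, and it stays within the scatter. Read one bond further out as allyl to hexyl, the change both lengthens the chain and removes the double bond outside aromatic rings, and the two together leave the read-out within the scatter; this single step cannot separate them. Nothing at hand gives a measured reason for the size of this step.

On these data alone, whether a propyl chain, which would keep the length of allyl without its double bond, gives the same read-out remains open. Also open, as far as these compounds go, is whether a longer chain, or a chain ending in an amine or a carboxylic acid, moves the number beyond the scatter.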